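Amino for dimethylamino, carried from one core to another

The source may report more compounds than this note shows. Statements on the series, on what has been measured and on what is new or still open speak of the compounds shown alone.

Compound 1 `COc1ccc(C(=O)c2ccc(OC)c3c2C=CC(C)(C)O3)c(NC(=O)CN)c1` and compound 2 `COc1ccc(C(=O)c2ccc(OC)c3c2C=CC(C)(C)O3)c(NC(=O)CN(C)C)c1` share one core and differ only at the end of the side chain. In a functional assay on MCF7 cells (Homo sapiens) for antiproliferative activity, read by MTT assay, with a stated time of 48 h (a lower number here means a stronger inhibitor, a higher number a weaker inhibitor), compound 2 gives 6530 nM, while compound 1 gives 1250 nM. The change amino in place of dimethylamino on a saturated chain carbon bound to a carbonyl carbon thus produced a 5.2-fold lower number from compound 2 to compound 1 (0.72 log units; beyond the scatter).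

Compound 3 `COc1ccc(C(=O)c2cc(OC)c(OC)c(OC)c2)c(NC(=O)CN(C)C)c1` carries the dimethylamino end on a different core; the difference between the core of compound 2 and the core of compound 3 is not broken down here. In this assay compound 3 gives 790 nM, which is within the usual scatter of the number for compound 1, whereas compound 2 gives a number beyond the scatter above it.

Compound 4 `COc1ccc(C(=O)c2cc(OC)c(OC)c(OC)c2)c(NC(=O)CN)c1` is not yet measured. It differs from compound 3 by amino in place of dimethylamino on a saturated chain carbon bound to a carbonyl carbon, the same change as from compound 2 to compound 1, made at the same place. Whether the step transfers to the second core cannot be known from two compounds on that core, so the expectation rests on a single precedent. Compound 4 is expected to give 200 nM in this assay. Its number is estimated to fall between 60 nM and 700 nM. Among the measured compounds shown here, the estimated step is a 4.0-fold lower number from compound 3 to compound 4 (0.60 log units; beyond the scatter), expected because a 5.2-fold lower number from compound 2 to compound 1 (0.72 log units; beyond the scatter) in the only matched pair measured so far.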

Compound 4, half-maximal inhibitory concentration: 270 nM
Compound 4: middle estimate off by 1.4-fold (0.13 log units), on the low side, and the stated range covers the measured number.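

In this assay the second core responds to the change in the same direction as the first: amino in place of dimethylamino on a saturated chain carbon bound to a carbonyl carbon gives a 2.9-fold lower number from compound 3 to compound 4 (0.47 log units; beyond the scatter) and so lowers the number on this core too. Set side by side, the two steps cannot be told apart in size: the same change on two cores in this assay, a 5.2-fold lower number (0.72 log units; beyond the scatter) from compound 2 to compound 1 and a 2.9-fold lower number (0.47 log units; beyond the scatter) from compound 3 to compound 4, 1.8-fold (0.25 log units) apart, within the scatter of two such steps

Among the compounds shown here, this supports carrying the change from one core to the other, but it rests on only two matched pairs in a single cell assay, so it shows neither a rule for other cores nor why the amino compounds give the lower numbers.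

The compounds shown leave open whether the trend runs through a methylamino end, which carries one methyl group where dimethylamino carries two, or whether it extends to a pyrrolidine ring or a hydroxyl group at the same place. They also leave open what a longer chain carrying the amino end would do on either core, and whether the two steps would stay alike on a third core.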